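Swapping Fluoro for Hydroxymethyl on a Saturated Ring

The source may report more compounds than this note shows. Statements on the series, on what has been measured and on what is new or still open speak of the compounds shown alone.

Of the compounds shown here, two have so far been measured in an assay on Sf9 cells for inhibition of Leucine-rich repeat serine/threonine-protein kinase 2 (Homo sapiens), read by TR-FRET, with stated times of 30 min and 2 h; a lower number here means a stronger inhibitor, a higher number a weaker inhibitor. Compound 1 `O=C(Nc1ccnnc1)c1cc(N2CCC(F)CC2)ccc1OCc1ccccc1` gives 39.8 nM in this assay, the higher of the two numbers and thus the weaker inhibitor of the pair. Compound 2 `N#Cc1cccc(NC(=O)c2cc(C(F)(F)F)ccc2OCc2ccc(F)cc2)c1` shares the amide linkage but differs from compound 1 in several places; in this assay compound 2 gives 7.94 nM. The gap between compound 1 and compound 2 lies beyond the usual scatter of repeated measurements. For the measured compounds named here, the two differ in more than one place, so no single step between them can be read.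

Compound 3 `O=C(Nc1ccnnc1)c1cc(N2CCC(CO)CC2)ccc1OCc1ccccc1` has not yet been measured. It is derived from compound 1 by one change: hydroxymethyl in place of fluoro on a saturated ring carbon. Going by the values given here, no measured pair shows this kind of change, so there is no direct guide to its effect. The expectation is that the step of a 1.1-fold higher number from compound 1 to compound 3 (0.05 log units; within the scatter) is small, within the scatter, with a modest chance of weakening. Compound 3 is therefore expected to give about 45 nM in this assay, with a range from 12 nM to 180 nM.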

Compound 3, half-maximal inhibitory concentration: 20 nM
Beside the measured number, compound 3's estimate is 2.3-fold (0.35 log units) above it, and the stated range covers the measured number.
By their numbers in this assay, from the lowest: compound 2; then compounds 3 and 1 (each within the scatter of the next).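

In this assay, going from 4-fluoropiperidin-1-yl to 4-(hydroxymethyl)piperidin-1-yl gives a 2.0-fold lower number from compound 1 to compound 3 (0.30 log units; within the scatter), so this pair cannot be told apart by this measurement. For the compounds shown here, this is the first direct reading at this saturated ring carbon, three ring bonds from the ring nitrogen, and it shows that the position accepts hydroxymethyl, with its hydrogen-bond donor and hydrogen-bond acceptor, in place of fluoro without a change beyond the scatter. No supporting data are available to explain this result.

This single pair is all that speaks for the position, and compound 2 differs from both other compounds in more than one place, so it adds no readable step here. Going by these compounds, whether the same tolerance would hold for a longer chain such as hydroxyethyl, for a carboxylic acid, or for an amine on this ring carbon remains open, as does whether hydroxymethyl would behave the same way on a different core.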